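Furan in place of the biaryl nitrile of compound 1

The source may report more compounds than this note shows. Statements on the series, on what has been measured and on what is new or still open speak of the compounds shown alone.

Going by the values given here, compound 1 `COc1cc(CC(O)c2ccc(-c3ccc(C#N)cc3)cc2)c([N+](=O)[O-])cc1OC` carries the lowest of the three numbers so far in an ADME assay on HeLa Rh cells (Homo sapiens) for cytotoxicity, read by microscopy (a higher number here means that more compound is tolerated, a lower number that less compound is tolerated), at 4700 nM, though all three sit within the scatter of one another. Compound 2 `COc1cc(CC(O)c2ccc(-c3cccc(F)c3)cc2)c([N+](=O)[O-])cc1OC` gives 7400 nM and compound 3 `COc1cc(CC(O)c2ccc(-c3ccccc3C#N)cc2)c([N+](=O)[O-])cc1OC` gives 9300 nM; the steps of a 1.6-fold higher number from compound 1 to compound 2 (0.20 log units; within the scatter), a 2.0-fold higher number from compound 1 to compound 3 (0.30 log units; within the scatter) and a 1.3-fold higher number from compound 2 to compound 3 (0.10 log units; within the scatter) are each within the scatter. Compound 4 `COc1cc(CC(O)c2ccc(-c3ccoc3)cc2)c([N+](=O)[O-])cc1OC` differs from compound 1 by furan-3-yl in place of 4-cyanophenyl on an aromatic carbon. Among the compounds with values here, no measured step replaces a six-membered aromatic ring of carbon only with a five-membered aromatic ring with 1 hetero atom, so the bearing of the known steps is indirect; since every one of them stayed within the scatter, no step beyond the scatter is expected in this assay. For compound 4 the expected value is 6000 nM, with a range of 3000 nM to 12000 nM, which is estimated as a step of a 1.3-fold higher number from compound 1 to compound 4 (0.11 log units; within the scatter).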

Compound 4, half-maximal cytotoxic concentration: 5300 nM
For compound 4 the middle estimate is 1.1-fold (0.05 log units) above the measured one, within the range that was stated.
By their numbers in this assay, from the lowest: compounds 1, 4, 2 and 3 (each within the scatter of the next).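

In this assay, furan-3-yl on an aromatic carbon para to a large group gives the first five-membered aromatic ring with 1 hetero atom at this position, and the steps of a 1.1-fold higher number from compound 1 to compound 4 (0.05 log units; within the scatter) and a 1.4-fold lower number from compound 2 to compound 4 (0.14 log units; within the scatter) and a 1.8-fold lower number from compound 3 to compound 4 (0.24 log units; within the scatter) stay within the scatter. Across these four compounds, neither ring size nor the presence of a nitrile separates the numbers beyond the scatter.

On these data alone, whether an amine or a carboxylic acid on this aromatic carbon would give a step beyond the scatter remains open. No data on hand explain this flat result.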